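A few compounds are considered here, and "the series" means these few. Any claim that something is new, unique, unknown or untested is made for them only; others in the source may bear on it.

Measured compounds:
- compound 1, `CNS(=O)(=O)NC[C@@H]1CCCc2cc(S(=O)(=O)c3cccc(F)c3)ccc21`, which in an assay on isolated protein for displacement of a labelled ligand from 5-hydroxytryptamine receptor 6 (Homo sapiens) (on this read-out lower numbers stand for stronger inhibition and higher numbers for weaker inhibition), gives 1 nM
- compound 2, `O=C(NC[C@@H]1CCCc2cc(S(=O)(=O)c3cccc(F)c3)ccc21)[C@H]1CCCN1`, which in this assay gives 0.631 nM
- compound 3, `CNC(=O)NC[C@@H]1CCCc2cc(S(=O)(=O)c3cccc(F)c3)ccc21`, which in this assay gives 0.398 nM

Compound 3 has the lowest number of the three, but only its distance from compound 1 is beyond the scatter (a 2.5-fold lower number from compound 1 to compound 3 (0.40 log units; beyond the scatter)); against compound 2 the difference is a 1.6-fold lower number from compound 2 to compound 3 (0.20 log units; within the scatter), so these two cannot be ranked.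

Compound 4, `CC(C)(C)C(=O)NC[C@@H]1CCCc2cc(S(=O)(=O)c3cccc(F)c3)ccc21`, is not yet measured. It differs from compound 3 in one place: tert-butyl in place of methylamino on a carbonyl carbon. The step that bears most directly on this is the one on the same carbonyl carbon, a 1.6-fold lower number from compound 2 to compound 3 (0.20 log units; within the scatter), where a different group on that carbon changed little. The other steps, a 1.6-fold lower number from compound 1 to compound 2 (0.20 log units; within the scatter) and a 2.5-fold lower number from compound 1 to compound 3 (0.40 log units; beyond the scatter), show that replacing the whole group on the amine nitrogen also moved the number only modestly. All three measured compounds sit close together, so in this assay the change to compound 4 is expected to stay small, most likely a slightly higher number, with a 2.5-fold higher number from compound 3 to compound 4 (0.40 log units; beyond the scatter) as the estimated step.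

For compound 4 the estimate in this assay is 1 nM, with a range from 0.3 nM to 4 nM.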

Compound 4, inhibition constant: 3.98 nM
The estimate for compound 4 lay 4.0-fold (0.60 log units) below the measured number, and the stated range covers the measured number.
By their numbers in this assay, from the lowest: compounds 3, 2 and 1 (each within the scatter of the next, the first and the last beyond it); then compound 4.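

The carbonyl carbon, which had seemed to accept different groups with little change, proves sensitive to this replacement in this assay: tert-butyl in place of methylamino gives the largest step in the set (a 10-fold higher number from compound 3 to compound 4 (1.00 log units; beyond the scatter)). Among the compounds shown here, compound 4 also lies beyond the scatter of the other two compounds (a 6.3-fold higher number from compound 2 to compound 4 (0.80 log units; beyond the scatter); a 4.0-fold higher number from compound 1 to compound 4 (0.60 log units; beyond the scatter)), making it the weakest of the four on this read-out, so the tolerance suggested by the earlier compounds does not extend to every group at this position. This swap removes the hydrogen-bond donor of methylamino and brings in 4 carbon atoms where 2 heavy atoms stood, and no measurement here accounts for the weaker result.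

The compounds shown change these two features together, so the contribution of each remains open. Placing a methyl or an ethyl on the same carbonyl carbon would test a smaller carbon group with no donor, while dimethylamino would test a nitrogen-linked group with no donor.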